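Pyridin-4-yl for 4-fluorophenyl: estimating compound 4

The source may hold more compounds than are shown below. What is called first, only, known or untested is meant among the compounds shown, and "the series" means these compounds.

The series in a functional assay on HepG2 cells (Homo sapiens) for cytotoxicity, read by MTT assay, with a stated time of 48 h (on this read-out lower numbers stand for stronger inhibition and higher numbers for weaker inhibition), comprises compound 1 `CC(C)=CCC/C(C)=C/CC/C(C)=C/CC[C@@H]1[C@@]2(C)CC/C(=N\OCc3cn(-c4ccccc4C#N)nn3)C(C)(C)[C@@H]2CC[C@@]1(C)O` with 21900 nM, compound 2 `CC(C)=CCC/C(C)=C/CC/C(C)=C/CC[C@@H]1[C@@]2(C)CC/C(=N\OCc3cn(-c4ccc(F)c(Cl)c4)nn3)C(C)(C)[C@@H]2CC[C@@]1(C)O` with 58900 nM, and compound 3 `CC(C)=CCC/C(C)=C/CC/C(C)=C/CC[C@@H]1[C@@]2(C)C/C(=C\c3ccc(OCc4cn(-c5ccc(F)cc5)nn4)cc3)C(=O)C(C)(C)[C@@H]2CC[C@@]1(C)O` with 35900 nM. Compound 3 stands second highest of the three numbers; its gaps to compound 1 and to compound 2 are both within the scatter, so no order can be read among these three. For the measured compounds named here, the only step that differs in a single place, a 2.7-fold higher number from compound 1 to compound 2 (0.43 log units; beyond the scatter), shows that exchanging the aryl group on an aromatic nitrogen moves the read-out modestly.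

Compound 4 `CC(C)=CCC/C(C)=C/CC/C(C)=C/CC[C@@H]1[C@@]2(C)C/C(=C\c3ccc(OCc4cn(-c5ccncc5)nn4)cc3)C(=O)C(C)(C)[C@@H]2CC[C@@]1(C)O` is not yet measured. It differs from compound 3 in one place: pyridin-4-yl in place of 4-fluorophenyl on an aromatic nitrogen. Pyridin-4-yl in place of 4-fluorophenyl on an aromatic nitrogen has no direct precedent here; the one related exchange at that kind of position is the step from compound 1 to compound 2, which sits on a differently built core and swaps a different pair of groups, so it bears on compound 4 only loosely. It suggests that aryl exchanges at this position shift the number by modest amounts at most. For compound 4 the step is expected to be a 1.1-fold higher number from compound 3 to compound 4 (0.05 log units; within the scatter), with either direction possible and probably not beyond the scatter. The estimate for compound 4 is 40000 nM, with a range from 15000 nM to 100000 nM.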

Compound 4, half-maximal inhibitory concentration: 105000 nM
Compound 4: the middle estimate sits 2.6-fold (0.42 log units) below what was measured, outside the stated range (above it).
By their numbers in this assay, from the lowest: compounds 1, 3, 2 and 4 (each within the scatter of the next, the first and the last beyond it).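

In this assay, pyridin-4-yl in place of 4-fluorophenyl on an aromatic nitrogen of the five-membered aromatic ring with 3 nitrogen gives a 2.9-fold higher number from compound 3 to compound 4 (0.47 log units; beyond the scatter), so this exchange moves the read-out beyond the scatter towards weaker inhibition. With a 2.7-fold higher number from compound 1 to compound 2 (0.43 log units; beyond the scatter), there are now two single-place aryl exchanges on this nitrogen, one on each of two differently built cores, and both lie beyond the scatter, so the group at this position is not silent on either core, although the two steps swap different pairs of groups and give no common ranking of aryl groups. The change replaces a fluorine-bearing ring of carbon only with a ring holding one hetero atom and one hydrogen-bond acceptor, but nothing at hand explains why the number moves.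

As far as these compounds go, whether the step follows the ring nitrogen or the loss of fluorine stays open, and an unsubstituted phenyl or a pyridin-3-yl on the same nitrogen would help to separate the two. Also open, from the compounds shown here alone, is whether pyridin-4-yl in place of 4-fluorophenyl would give a similar step on the core of compound 1.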